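Working notes: trifluoromethyl in place of cyano

The source may report more compounds than this note shows. Statements on the series, on what has been measured and on what is new or still open speak of the compounds shown alone.

compound 1 `Cc1cc(-c2ccc3cc[nH]c3c2)cc(C)c1Nc1ccnc(Nc2ccc(C#N)cc2)n1` gives 5800 nM
compound 2 `Cc1cc(-c2cnc(C#N)nc2)cc(C)c1Nc1ccnc(Nc2ccc(C#N)cc2)n1` gives 3100 nM

In a toxicity assay on MT4 cells (Homo sapiens) for cytotoxicity, read by MTT assay, with a stated time of 5 days (on this read-out lower numbers stand for higher toxicity in this test and higher numbers for lower toxicity in this test), compound 2 stands at 3100 nM and so within the scatter of compound 1. Within the data shown here, the one measured step is a 1.9-fold lower number from compound 1 to compound 2 (0.27 log units; within the scatter) and it concerns a different exchange, 2-cyanopyrimidin-5-yl in place of 1H-indol-6-yl. Compound 3 `Cc1cc(-c2cnc(C(F)(F)F)nc2)cc(C)c1Nc1ccnc(Nc2ccc(C#N)cc2)n1` carries trifluoromethyl in place of cyano on an aromatic carbon and is thus trifluoromethyl in place of cyano on an aromatic carbon. No measurement covers this exchange directly. No change beyond the scatter is expected in this assay and no direction is favoured, the estimated outcome being a 1.1-fold higher number from compound 2 to compound 3 (0.05 log units; within the scatter) in size. Compound 3 is estimated at 3500 nM (1500 nM to 8000 nM).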

Compound 3, half-maximal cytotoxic concentration: 4900 nM
Compound 3: the middle estimate sits 1.4-fold (0.15 log units) below what was measured, within the range that was stated.
By their numbers in this assay, from the lowest: compounds 2, 3 and 1 (each within the scatter of the next).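

Trifluoromethyl in place of cyano on the aromatic carbon between two ring nitrogen atoms gives, in this assay, a 1.6-fold higher number from compound 2 to compound 3 (0.20 log units; within the scatter) and is the first reading of an exchange at this carbon itself. Against the indole end of the series, 2-(trifluoromethyl)pyrimidin-5-yl in place of 1H-indol-6-yl gives a 1.2-fold lower number from compound 1 to compound 3 (0.07 log units; within the scatter) and so leaves all three compounds within the scatter of one another. No measurement at hand speaks to the cause of these numbers.

Open, going by these compounds, is whether an amine or a carboxylic acid on this carbon would give a step beyond the scatter. Also open, on these data alone, is whether the exchange reads the same on a different core.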